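The source may report more compounds than this note shows. Statements on the series, on what has been measured and on what is new or still open speak of the compounds shown alone.

Compound 3 `CCc1ccccc1-n1nncc1CN1C(=O)C2(C(C#N)=C(N)Oc3c(N)cc4nc5ccccc5nc4c32)c2ccccc21` is the only one of the three measured compounds with an actual number in a functional assay on HCT-116 cells (Homo sapiens) for antiproliferative activity, read by MTT assay, with a stated time of 48 h (a higher number here means a weaker inhibitor, a lower number a stronger inhibitor), where compound 3 gives 10300 nM. Compound 1 `N#CC1=C(N)Oc2c(c3nc4ccccc4nc3c3ccccc23)C12C(=O)N(Cc1cnnn1-c1cccc(Cl)c1)c1ccccc12` reaches only a limit of the assay, > 50000 nM. Compound 2 `COc1ccc(-n2nncc2CN2C(=O)C3(C(C#N)=C(N)Oc4c3c3nc5ccccc5nc3c3ccccc43)c3ccccc32)cc1` likewise stops at a limit, > 50000 nM. Going by the values given here, the step that the two limits leave unreadable from compound 1 to compound 2 is the one measured change on the aromatic nitrogen, and its size cannot be read because both ends sit at the limit of > 50000 nM in this assay, at which 2 of the 3 values shown sit. Compound 4 `Cc1ccc(-n2nncc2CN2C(=O)C3(C(C#N)=C(N)Oc4c(N)cc5nc6ccccc6nc5c43)c3ccccc32)cc1Cl` differs from compound 3 by 3-chloro-4-methylphenyl in place of 2-ethylphenyl on an aromatic nitrogen. No readable step bears on this change, so no shift beyond the scatter is expected. Compound 4 is therefore estimated at 10000 nM, within 3000 nM to 40000 nM. The expected step of a 1.0-fold lower number from compound 3 to compound 4 (0.01 log units; within the scatter) is accordingly small.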

Compound 4, half-maximal inhibitory concentration: > 50000 nM
Compound 4 ended at the assay's limit; the forecaster's own chance of this, stated with the estimate: 25%; at least 5.0-fold (0.69 log units) between middle value and limit.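

Going by these compounds alone, on an aromatic nitrogen, 3-chloro-4-methylphenyl in place of 2-ethylphenyl gives the first readable change at this position: an at least 4.8-fold higher number from compound 3 to compound 4 (0.68 log units; beyond the scatter) in this assay. Within the data shown here, the earlier step at this position cannot be read, so this is the first sign that the group there can move the result beyond the scatter. Compound 4 itself gives a limit and not a number: the limit of > 50000 nM in this assay, at which 3 of the 4 values shown sit.

The compounds shown do not separate the part played by the chlorine, the methyl and the loss of the ethyl. They also leave open how a plain phenyl or a 2-methoxyphenyl would read in this assay.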